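The source may hold more compounds than are shown below. What is called first, only, known or untested is meant among the compounds shown, and "the series" means these compounds.

Compound 3 `COc1ccc(C(=O)c2cc(OC)c(OC)c(OC)c2)cc1NC(=O)/C=C/c1ccc(F)c(F)c1` gives the highest of three numbers in a functional assay on HeLa cells (Homo sapiens) for cytotoxicity, read by MTT assay, with a stated time of 72 h (on this read-out higher numbers stand for weaker inhibition and lower numbers for stronger inhibition), where compound 3 reads 8100 nM. Its nearest neighbour is compound 1 `COc1ccc(C(=O)c2cc(OC)c(OC)c(OC)c2)cc1NC(=O)/C=C/c1ccc(OC)c(OC)c1`, which in this assay gives 7800 nM, a difference within the scatter a 1.0-fold higher number from compound 1 to compound 3 (0.02 log units; within the scatter). Further away stands compound 2 `COc1cccc(/C=C/C(=O)Nc2cc(C(=O)c3cc(OC)c(OC)c(OC)c3)ccc2OC)c1`, which in this assay gives 3100 nM; the step of a 2.6-fold higher number from compound 2 to compound 3 (0.42 log units; beyond the scatter) is modest but beyond the scatter. The step to compound 4 `COc1ccc(C(=O)c2cc(OC)c(OC)c(OC)c2)cc1NC(=O)/C=C/c1ccc(N)cc1` is 4-aminophenyl in place of 3,4-difluorophenyl on a double-bonded chain carbon bound to a double-bonded chain carbon. Both measured steps that reach compound 3 exchange the aryl group on the same double-bonded chain carbon: the exchange a 1.0-fold higher number from compound 1 to compound 3 (0.02 log units; within the scatter) leaves the number unchanged, while a 2.6-fold higher number from compound 2 to compound 3 (0.42 log units; beyond the scatter) is modest. Neither step involves an aminophenyl, so the direction is not shown, but both suggest that exchanging the aryl at this place moves the number by at most a modest amount. The step of a 1.4-fold lower number from compound 3 to compound 4 (0.13 log units; within the scatter) is therefore expected to stay small. Compound 4 is estimated in this assay at 6000 nM, within a range from 2500 nM to 15000 nM.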

Compound 4, half-maximal inhibitory concentration: 14700 nM
Compound 4: the middle estimate sits 2.5-fold (0.39 log units) below what was measured; the measured number falls inside the stated range.
By their numbers in this assay, from the lowest: compound 2; then compounds 1, 3 and 4 (each within the scatter of the next).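

Among these compounds, compound 4 brings the first amine to this place, on a double-bonded chain carbon bound to a double-bonded chain carbon, and the first aryl group here with a hydrogen-bond donor. In this assay, 4-aminophenyl cannot be told apart from 3,4-difluorophenyl (a 1.8-fold higher number from compound 3 to compound 4 (0.26 log units; within the scatter)) or from 3,4-dimethoxyphenyl (a 1.9-fold higher number from compound 1 to compound 4 (0.28 log units; within the scatter)), while the 3-methoxyphenyl of compound 2 still stands apart (a 4.7-fold higher number from compound 2 to compound 4 (0.68 log units; beyond the scatter)), a modest step. Among the four compounds, then, only compound 2 separates from the rest, and nothing shown gives a reason for this.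

The compounds shown leave open whether the separation belongs to a lone methoxy group or to its place on the ring. They also leave open how an unsubstituted phenyl, a 3-aminophenyl or a 4-carboxyphenyl would read here.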